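The compounds below may be only part of what the source reports. "The series", "measured", "known", "first", "only" and "open" are said of these compounds alone.

Compound 1 `O=C(CSC(=S)N[C@H]1CCOC1=O)Nc1ccc(Br)cc1` gives 67400 nM
Compound 2 `Cc1cccc(NC(=O)CSC(=S)N[C@H]2CCOC2=O)c1C` gives > 128000 nM (a limit of the assay, not a number)
Compound 3 `O=C(CSC(=S)N[C@H]1CCOC1=O)Nc1ccccc1` gives > 128000 nM (a limit of the assay, not a number)

Among the compounds with values here, in a functional assay on EC9706 cells (Homo sapiens) for cytotoxicity, read by MTT assay, with a stated time of 72 h (on this read-out higher numbers stand for weaker inhibition and lower numbers for stronger inhibition), compound 1 gives 67400 nM as the only true number here. The other two entries sit at the limit of > 128000 nM in this assay, at which 2 of the 3 values shown sit, and are limits only.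

The next compound is compound 4 `O=C(CSC(=S)N[C@H]1CCOC1=O)Nc1ccccc1Cl`, and its change is 2-chlorophenyl in place of 4-bromophenyl on an amide-type nitrogen. Within the data shown here, no measured compound carries 2-chlorophenyl, so the evidence is indirect. Among the measured compounds shown here, the one measured step that bears on it is an at least 1.8-fold higher number from compound 1 to compound 3 (0.27 log units; that floor lies within the scatter), which also removes the bromo. On the strength of that step, compound 4 is expected to lean toward a higher number, with no clear move beyond the usual scatter. The estimated step is a 1.5-fold higher number from compound 1 to compound 4 (0.17 log units; within the scatter), a small one toward weaker inhibition. Compound 4 is estimated at 100000 nM, with an expected range from 45000 nM to 200000 nM, and it may yet return only a limit.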

Compound 4, half-maximal inhibitory concentration: > 128000 nM
Compound 4: a limit, no number; the forecaster's own chance of this, stated with the estimate: 45%; at least 1.2-fold (0.10 log units) between middle value and limit.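

In this assay compound 4 gives a limit, not a number, so a halogen on the aromatic ring does not by itself bring a readable value. Putting 2-chlorophenyl in place of 4-bromophenyl on the amide-type nitrogen gives an at least 1.8-fold higher number from compound 1 to compound 4 (0.27 log units; that floor lies within the scatter), so this change cannot be shown to matter beyond ordinary variation between repeats. Compound 3 and compound 4 are both limits, so the step between them cannot be read, and compound 1 remains the only compound with a true number, the others sharing one ceiling: the limit of > 128000 nM in this assay, at which 3 of the 4 values shown sit.

As far as these compounds go, whether the kind of halogen or its place on the ring counts stays open, and a 4-chlorophenyl group on the same nitrogen would separate the two. Also open, from the compounds shown here alone, is how a 4-aminophenyl group or a 4-carboxyphenyl group at this nitrogen would read.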